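Ring methyl step carried from one core to another

The compounds below may be only part of what the source reports. "The series", "measured", "known", "first", "only" and "open" are said of these compounds alone.

Measured so far in a functional assay on the whole organism for agonist activity, with Mus musculus as the target; a lower number here means that less compound is needed, a higher number that more compound is needed for the effect:
compound 1, `COC(=O)N(C)C(C)C#CCn1ccnc1`, 8 mg/kg
compound 2, `COC(=O)N(C)C(C)C#CCn1cncc1C`, with a limit only
compound 3, `O=C1NCCN1CC#CCn1ccnc1`, 17.3 mg/kg

Compound 2 gives only a limit in this assay, > 100 mg/kg, and not a number. Among the two numbers compound 3 stands highest; the nearest to it is compound 1, and the gap between the two lies beyond the scatter. The difference between the core of compound 1 and the core of compound 3 is not broken down here.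

Between compound 1 and compound 2 the change is methyl in place of hydrogen on an aromatic carbon. It produced an at least 12-fold higher number from compound 1 to compound 2 (1.09 log units; beyond the scatter); the measured side of that step is a limit, (the limit of > 100 mg/kg in this assay, at which 1 of the 3 values shown sits), so only its lower bound is known.

Compound 4, `Cc1cncn1CC#CCN1CCNC1=O`, is not yet measured. Among the measured compounds shown here, it differs from compound 3 by methyl in place of hydrogen on an aromatic carbon, the same kind of change as the one made from compound 1 to compound 2, on a ring of the same description but within the core of compound 3.

For compound 4 the step expected in this assay is an 8.7-fold higher number from compound 3 to compound 4 (0.94 log units; beyond the scatter), resting on the step seen from compound 1 to compound 2 (an at least 12-fold higher number from compound 1 to compound 2 (1.09 log units; beyond the scatter)) and on the value of compound 3 (17.3 mg/kg). Compound 4 is therefore estimated at 150 mg/kg, with a range from 40 mg/kg to 600 mg/kg, and a good chance that only a limit is reported.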

Compound 4, dose for half-maximal effect: > 100 mg/kg
Compound 4 was reported as a limit; the forecaster's own chance of this, stated with the estimate: 60%; the middle value is on the limit's open side.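

In this assay methyl in place of hydrogen on an aromatic carbon goes the same way on the core of compound 3 as on the core of compound 1, with an at least 5.7-fold higher number from compound 3 to compound 4 (0.76 log units; beyond the scatter), so in these two pairs the direction of the step carries from one core to the other: the same change on two cores in this assay, an at least 12-fold higher number (1.09 log units; beyond the scatter) from compound 1 to compound 2 and an at least 5.7-fold higher number (0.76 log units; beyond the scatter) from compound 3 to compound 4; the limit leaves it open whether they differ

Compound 4 gives only a limit, > 100 mg/kg, and not a number.

The true size of the step therefore remains unknown on both cores, so nothing can be said about whether the core changes it, and two pairs make no general rule for the series: the limit of > 100 mg/kg in this assay, at which 2 of the 4 values shown sit.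

Still open, on these data alone, is how other groups behave on the same aromatic carbon, next to the ring atom that bears a large group: an ethyl or a chlorine there might give a number rather than a limit in this assay, and that would begin to show how much substitution this place tolerates. Also open, as far as these compounds go, is whether a methyl on one of the other aromatic carbons of the ring costs as much on either core, which would show whether the loss belongs to this place or to the ring as a whole.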